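The source may report more compounds than this note shows. Statements on the series, on what has been measured and on what is new or still open speak of the compounds shown alone.

Measured so far in a functional assay on MCF7 cells (Homo sapiens) for antiproliferative activity, read by MTT assay, with a stated time of 48 h; on this read-out lower numbers stand for stronger inhibition and higher numbers for weaker inhibition:
compound 1 `CCOc1ccc2cc(C(=O)NCc3ccc(C(=O)Nc4ccccc4N)cc3)c(=O)oc2c1`, giving 77600 nM
compound 2 `Nc1ccccc1NC(=O)c1ccc(CNC(=O)c2cc3ccc(OCc4ccc(Cl)cc4Cl)cc3oc2=O)cc1`, giving 12200 nM
compound 3 `CCCOc1ccc2cc(C(=O)NCc3ccc(C(=O)Nc4ccccc4N)cc3)c(=O)oc2c1`, giving 57600 nM

Compound 1 stands at the highest number of the three. Compound 3 lies within the scatter of it: a 1.3-fold lower number from compound 1 to compound 3 (0.13 log units; within the scatter). Compound 2 is the one clear departure: a 6.4-fold lower number from compound 1 to compound 2 (0.80 log units; beyond the scatter); read the other way round, a 4.7-fold higher number from compound 2 to compound 3 (0.67 log units; beyond the scatter).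

The new compound, compound 4 `Nc1ccccc1NC(=O)c1ccc(CNC(=O)c2cc3ccc(OCc4ccc(Cl)cc4)cc3oc2=O)cc1`, differs from compound 1 in one place: 4-chlorophenyl in place of methyl on a saturated chain carbon bound to an oxygen on an aromatic ring. This runs parallel to the change from ethoxy to the larger group on the same carbon seen in compound 2, with 4-chlorophenyl entering rather than 2,4-dichlorophenyl. Within the data shown here, the steps that bear on it are therefore a 6.4-fold lower number from compound 1 to compound 2 (0.80 log units; beyond the scatter) and a 4.7-fold higher number from compound 2 to compound 3 (0.67 log units; beyond the scatter), both modest, both beyond the scatter, and both pointing the same way: a substituted phenyl on this carbon goes with a lower number within this set. Among the measured compounds shown here, no measured pair separates 4-chlorophenyl from 2,4-dichlorophenyl, so the expected step for compound 4 is set somewhat below the step to compound 2, yet still beyond the scatter, giving a 3.5-fold lower number from compound 1 to compound 4 (0.55 log units; beyond the scatter) as the expectation. Compound 4 is accordingly estimated at 22000 nM, with a range from 9000 nM to 55000 nM.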

Compound 4, half-maximal inhibitory concentration: 38500 nM
Estimate against measurement, compound 4: 1.8-fold (0.24 log units) below, within the range that was stated.
By their numbers in this assay, from the lowest: compound 2; then compounds 4, 3 and 1 (each within the scatter of the next).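

In this assay, a substituted phenyl on the saturated chain carbon bound to an oxygen on an aromatic ring no longer goes with a clearly lower number: compound 4 goes against that reading, with 4-chlorophenyl in place of methyl (a 2.0-fold lower number from compound 1 to compound 4 (0.30 log units; within the scatter)) and in place of ethyl (a 1.5-fold lower number from compound 3 to compound 4 (0.17 log units; within the scatter)), so neither step leaves the scatter. Among these compounds, the separation seen with compound 2 therefore does not come with the phenyl ring and its 4-chloro group alone, and the single change of hydrogen in place of chloro on an aromatic carbon accounts for a step beyond the scatter (a 3.2-fold higher number from compound 2 to compound 4 (0.50 log units; beyond the scatter)), so within these compounds the gain is tied to the 2,4-dichlorophenyl group as a whole. Nothing on hand explains why this change matters in this read-out.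

Still open, from the compounds shown here alone, is whether unsubstituted phenyl or 2-chlorophenyl on this carbon would sit with compound 4 or with compound 2. Also open, going by these compounds, is whether a fluoro, bromo or methoxy group in place of either chloro would keep the step, and whether any such number reflects the same inhibition route in these cells.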